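Swapping the Ketone Aryl Group: From Aminopyrimidine to Indole

The source may report more compounds than this note shows. Statements on the series, on what has been measured and on what is new or still open speak of the compounds shown alone.

Of the compounds shown here, three sharing one core have been tested in a functional assay on H184B5F5/M10 cells (Homo sapiens) for antiproliferative activity, read by XTT assay, with a stated time of 72 h; on this read-out higher numbers stand for weaker inhibition and lower numbers for stronger inhibition. Compound 1, `COc1ccc(-c2cc3ccccc3nc2/C=C/C(=O)c2ccc(N)cc2)cc1`, gives 9290 nM. Compound 2, `COc1ccc(-c2cc3ccccc3nc2/C=C/C(=O)c2ccccn2)cc1`, gives 4140 nM, a step of a 2.2-fold lower number from compound 1 to compound 2 (0.35 log units; beyond the scatter). Compound 3, `COc1ccc(-c2cc3ccccc3nc2/C=C/C(=O)c2cnc(N)nc2C)cc1`, gives only > 10000 nM, which is a limit of the assay and not a number. Compound 3 therefore stands at the weak end of what has been measured: its step from compound 1 is an at least 1.0-fold higher number from compound 1 to compound 3 (0.03 log units; that floor lies within the scatter), and from compound 2 it is an at least 2.4-fold higher number from compound 2 to compound 3 (0.38 log units; beyond the scatter).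

The new compound 4, `COc1ccc(-c2cc3ccccc3nc2/C=C/C(=O)c2c[nH]c3ccccc23)cc1`, differs from compound 3 in one place: 1H-indol-3-yl in place of 2-amino-4-methylpyrimidin-5-yl on a carbonyl carbon. Within the data shown here, the two steps that bear on this site, the one from compound 1 to compound 3 and the one from compound 2 to compound 3, show that changing the ring on the carbonyl carbon moves the number by modest amounts, and that the 2-amino-4-methylpyrimidin-5-yl ring sits at the weak end. The 1H-indol-3-yl ring is expected to return compound 4 toward the range of compound 1 and compound 2, an estimated step of an at least 1.6-fold lower number from compound 3 to compound 4 (0.22 log units; that floor lies within the scatter). Compound 4 is therefore expected to give about 6000 nM, within roughly 1500 nM to 20000 nM.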

Compound 4, half-maximal inhibitory concentration: > 10000 nM
Compound 4: only a limit was reported; the forecaster's own chance of this, stated with the estimate: 25%; middle value at least 1.6-fold (0.22 log units) away from the limit.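

Two very different rings on the carbonyl carbon, the 1H-indol-3-yl of compound 4 and the 2-amino-4-methylpyrimidin-5-yl of compound 3, now end at the same limit of this assay, so reaching it is not peculiar to the aminopyrimidine: the limit of > 10000 nM in this assay, at which 2 of the 4 values shown sit.

Against the pyridin-2-yl ring, the indole gives an at least 2.4-fold higher number from compound 2 to compound 4 (0.38 log units; beyond the scatter), which leaves pyridin-2-yl as the best ring shown at this position. Against the 4-aminophenyl ring, the change gives only a floor, an at least 1.0-fold higher number from compound 1 to compound 4 (0.03 log units; that floor lies within the scatter), and the step between compound 3 and compound 4 cannot be read, with both resting on a limit.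

Going by these compounds, whether a plain phenyl or a pyridin-3-yl ring on the carbonyl carbon would read stronger than compound 2 at 4140 nM stays open. Also open, on these data alone, is how far past the limit compound 3 and compound 4 truly lie.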